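Ethylurea Side Chain and Cytotoxicity on Liver Cells

The compounds below may be only part of what the source reports. "The series", "measured", "known", "first", "only" and "open" are said of these compounds alone.

Compound 3 `O=C1O[C@@H](Cn2ccnc2)CN1c1ccc(-n2cc(-c3ccccn3)cn2)c(F)c1` carries an imidazolyl group on the side chain of the shared core. In an ADME assay on L02 cells (Homo sapiens) for cytotoxicity, read by MTT assay, with a stated time of 48 h (on this read-out lower numbers stand for stronger inhibition and higher numbers for weaker inhibition), compound 3 gives 350 ug/mL, the higher of the two numbers in hand. Compound 1 `CN1CCN(C[C@H]2CN(c3ccc(-n4cc(-c5ccccn5)cn4)c(F)c3)C(=O)O2)CC1`, which bears a methylpiperazinyl group in the same place, gives 70 ug/mL in this assay. Compound 2 `O=C1O[C@@H](CN2CCCCC2)CN1c1ccc(-n2cc(-c3ccccn3)cn2)c(F)c1`, with a piperidinyl group, sits at the limit of > 400 ug/mL in this assay, at which 1 of the 3 values shown sits, so only a limit, > 400 ug/mL, is known for it. Both a 5.0-fold higher number from compound 1 to compound 3 (0.70 log units; beyond the scatter) and an at least 5.7-fold higher number from compound 1 to compound 2 (0.75 log units; beyond the scatter) moved the number upward, whereas an at least 1.1-fold lower number from compound 2 to compound 3 (0.05 log units; that floor lies within the scatter) lies within the scatter.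

Compound 4 `CCNC(=O)NC[C@H]1CN(c2ccc(-n3cc(-c4ccccn4)cn3)c(F)c2)C(=O)O1` differs from compound 3 by (ethylcarbamoyl)amino in place of 1H-imidazol-1-yl on a saturated chain carbon bound to a saturated ring carbon. For the measured compounds named here, no measured step turns the imidazolyl group into a urea, so none bears directly on this change; the two steps out of compound 1 show that exchanging the methylpiperazinyl group raised the number, while the exchange between compound 2 and compound 3 did not shift it beyond the scatter. One therefore expects in this assay no step beyond the scatter: a 1.1-fold lower number from compound 3 to compound 4 (0.03 log units; within the scatter). Compound 4 is estimated at 330 ug/mL, within 150 ug/mL to 600 ug/mL.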

Compound 4, half-maximal inhibitory concentration: > 400 ug/mL
Compound 4: no number, only a limit; the forecaster's own chance of this, stated with the estimate: 40%; at least 1.2-fold (0.08 log units) between middle value and limit.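

In this assay compound 4 gives > 400 ug/mL, which is a limit of the assay and not a number, and it shares that limit with compound 2: (the limit of > 400 ug/mL in this assay, at which 2 of the 4 values shown sit). The rise on leaving the 4-methylpiperazin-1-yl group now also holds for a group with no ring, as (ethylcarbamoyl)amino on this saturated chain carbon gives an at least 5.7-fold higher number from compound 1 to compound 4 (0.75 log units; beyond the scatter), so compound 1 stands lowest of the compounds shown. By contrast, an at least 1.1-fold higher number from compound 3 to compound 4 (0.05 log units; that floor lies within the scatter) separates the urea from the imidazolyl group by no more than the scatter, and the step between compound 2 and compound 4 cannot be read.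

As far as these compounds go, it stays open whether the lower number of compound 1 goes with the piperazine ring itself or with its methyl group, which an unsubstituted piperazine or a morpholine would test. A primary amine or a longer chain on the urea also remains unexplored among the compounds shown.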